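Trimming the Amide Substituent of Compound 1

The compounds below may be only part of what the source reports. "The series", "measured", "known", "first", "only" and "open" are said of these compounds alone.

Compound 1, `CNC(=O)c1cc(C(=O)NC2CC2)cc2c1O[C@H](CF)[C@H]2c1ccccc1`: in a physicochemical assay for solubility (a higher number here means a more soluble compound, a lower number a less soluble compound), compound 1 gives 8 ug/mL.
Compound 2, `CNC(=O)c1cc(C(=O)N[C@H]2C[C@@H]2C)cc2c1OC[C@H]2c1ccccc1`: in this assay compound 2 gives >= 76 ug/mL, a limit of the assay and not a number.
Compound 3, `CNC(=O)c1cc(C(=O)NC2CC2)cc2c1OC[C@H]2c1ccccc1`: in this assay compound 3 gives >= 190 ug/mL, again a limit rather than a number.

Compound 1 is therefore the only compound of the three with a definite number; the other two values are limits, as shown by the limit of >= 190 ug/mL in this assay, at which 1 of the 3 values shown sits, and (the limit of >= 76 ug/mL in this assay, at which 1 of the 3 values shown sits). For the measured compounds named here, the one readable step, an at least 23-fold higher number from compound 1 to compound 3 (1.37 log units; beyond the scatter), is large. The step that the two limits leave unreadable from compound 2 to compound 3 cannot be sized.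

Compound 4, `CNC(=O)c1cc(C(N)=O)cc2c1O[C@H](CF)[C@H]2c1ccccc1`, differs from compound 1 by hydrogen in place of cyclopropyl on an amide-type nitrogen. Going by the values given here, neither measured step touches the amide-type nitrogen, so no measured step bears directly on this change. A large rise is shown only for the step of an at least 23-fold higher number from compound 1 to compound 3 (1.37 log units; beyond the scatter), at a different position. Compound 4 is expected to give 20 ug/mL, with a range from 7 ug/mL to 60 ug/mL. That estimate means an expected upward step of a 2.5-fold higher number from compound 1 to compound 4 (0.40 log units; beyond the scatter), modest and roughly at the edge of the scatter.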

Compound 4, solubility: >= 128 ug/mL
Compound 4: a limit, no number; the forecaster's own chance of this, stated with the estimate: 10%; at least 6.4-fold (0.80 log units) between middle value and limit.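

In this assay, hydrogen in place of cyclopropyl on the amide-type nitrogen is a large change on its own: an at least 16-fold higher number from compound 1 to compound 4 (1.20 log units; beyond the scatter). Among the earlier compounds, the only readable rise came from hydrogen in place of fluoromethyl on a saturated ring carbon, whereas compound 4 keeps the fluoromethyl group, so the amide-type nitrogen is a second place in compound 1 where a single change moves the read-out beyond the scatter. From the compounds shown here alone, the value of compound 4 is a limit and not a number, so the full size of this step remains unknown: the limit of >= 128 ug/mL in this assay, at which 1 of the 4 values shown sits.

The compounds shown leave open how an ethyl group or a longer chain ending in an amine on this nitrogen would read. Also open, going by these compounds, is how hydrogen on this nitrogen would read in the core of compound 3.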